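A Methyl Added to the Butyl Chain

The source may report more compounds than this note shows. Statements on the series, on what has been measured and on what is new or still open speak of the compounds shown alone.

In a functional assay on NCI-H460 cells (Homo sapiens) for antiproliferative activity, read by MTT assay, with a stated time of 48 h (a higher number here means a weaker inhibitor, a lower number a stronger inhibitor), compound 1 `CC(C)CCC1(O)C(=O)Nc2ccc(Nc3ccc(F)cc3)cc21` gives 16800 nM and compound 2 `CCCCC1(O)C(=O)Nc2ccc(Nc3ccc(Cl)cc3)cc21` gives 24400 nM as its value, which places compound 2 within the scatter of compound 1. Compound 3 `CC(C)CCC1(O)C(=O)Nc2ccc(Nc3ccc(Cl)cc3)cc21` departs from compound 2 by methyl in place of hydrogen on a saturated chain carbon bound to two saturated chain carbons on a saturated chain carbon bound to two saturated chain carbons, turning butyl into isopentyl. Among the measured compounds shown here, no measured step shows this change, so in this assay no shift beyond the scatter is expected in either direction. That expectation means an estimated 1.3-fold lower number from compound 2 to compound 3 (0.11 log units; within the scatter) in all. For compound 3 the estimated value is 19000 nM with an expected range from 10000 nM to 36000 nM for the measurement.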

Compound 3, half-maximal inhibitory concentration: 25000 nM
The estimate for compound 3 lay 1.3-fold (0.12 log units) below the measured number; measured number inside the range.
By their numbers in this assay, from the lowest: compounds 1, 2 and 3 (each within the scatter of the next).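

In this assay, methyl in place of hydrogen on a saturated chain carbon bound to two saturated chain carbons, turning butyl into isopentyl, moves the number by no more than the scatter (a 1.0-fold higher number from compound 2 to compound 3 (0.01 log units; within the scatter)). Chloro in place of fluoro on an aromatic carbon, now readable as a single change, also stays within the scatter (a 1.5-fold higher number from compound 1 to compound 3 (0.17 log units; within the scatter)). Nothing further is at hand to explain either result. The compounds shown leave open whether an amine or a longer chain in place of this methyl would give a step beyond the scatter. As far as these compounds go, whether bromo or methoxy in place of chloro on the aromatic carbon would do so also remains open.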